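Dropping One Methoxy From a Weak Enaminone

This account rests on a few compounds, and the source may have more. Where it says the series, first, only, none or still open, it means among the compounds named here.

Compound 1 `COc1ccc(N/C=C\C(=O)c2nc(-c3ccc(C(F)(F)F)cc3)n3ccccc23)cc1OC` was tested in a functional assay on MDA-MB-231 cells (Homo sapiens) for cytotoxicity, read by MTT assay, with a stated time of 48 h; on this read-out higher numbers stand for weaker inhibition and lower numbers for stronger inhibition. Compound 1 gives > 30000 nM, which is a limit of the assay rather than a number. Compound 1 therefore sits at the limit of > 30000 nM in this assay, at which 1 of the 2 values shown sits. Among the measured compounds shown here, compound 2 `O=C(/C=C\Nc1cnc2ccccc2c1)c1nc(-c2ccccc2)n2ccccc12` belongs to the same series, and in this assay compound 2 gives 12300 nM; no single-change step connects it to compound 1, so the two values show only that both are far from potent.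

Compound 3 `COc1ccc(N/C=C\C(=O)c2nc(-c3ccc(C(F)(F)F)cc3)n3ccccc23)cc1` differs from compound 1 by hydrogen in place of methoxy on an aromatic carbon. For the measured compounds named here, no measured step of this kind exists in this set, so its size and direction can only be expected. The expected step is an at least 1.2-fold lower number from compound 1 to compound 3 (0.07 log units; that floor lies within the scatter), given that the starting point sits at the limit of > 30000 nM in this assay, at which 1 of the 2 values shown sits, which leaves room for a change no larger than the scatter or a modest gain. The estimate for compound 3 is 25000 nM, between 8000 nM and 80000 nM.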

Compound 3, half-maximal inhibitory concentration: > 30000 nM
Compound 3 ended at the assay's limit (the forecaster's own chance of this, stated with the estimate: 55%); middle value at least 1.2-fold (0.07 log units) away from the limit.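

Among the compounds shown here, compound 1 and compound 3 both stop at a limit rather than a number, so no step between them can be read: the limit of > 30000 nM in this assay, at which 2 of the 3 values shown sit.

The compounds shown leave open whether hydrogen in place of methoxy changes the true potency of this weak pair in this assay at all.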